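Replacing the cyclopentyl of compound 2

The source may report more compounds than this note shows. Statements on the series, on what has been measured and on what is new or still open speak of the compounds shown alone.

Values so far in an ADME assay on microsomes (Rattus norvegicus) for metabolic stability (a lower number here means that the compound disappears faster, a higher number that the compound lasts longer), follow.
compound 1 `O=C(c1ccccc1)N1CCC(C(=O)N2N=CCC2c2ccccc2)CC1` gives 0.0833 h
compound 2 `O=C(C1CCCC1)N1N=CCC1c1ccccc1` gives 0.2 h
compound 3 `CC(C)(C)C(=O)N1N=CCC1c1cccnc1` gives > 1.5 h as a limit

Of the two actual numbers, compound 1 gives 0.0833 h and compound 2 gives 0.2 h. The number of compound 2 is the higher of these two, by a gap beyond the scatter. Compound 3 has only a limit of > 1.5 h and no number, so its place relative to compound 2 rests on that limit alone.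

Compound 4 `CC(C)(CO)C(=O)N1N=CCC1c1ccccc1` carries 1-(hydroxymethyl)-1-methylethyl in place of the cyclopentyl of compound 2 on a carbonyl carbon (1-(hydroxymethyl)-1-methylethyl in place of cyclopentyl on a carbonyl carbon). Among the measured compounds shown here, no measured pair shows this change on its own. A rise in this assay is expected, and the estimated move a 3.0-fold higher number from compound 2 to compound 4 (0.48 log units; beyond the scatter) lies beyond the scatter. The expectation leans on compound 3, which has no ring on that carbonyl carbon and whose > 1.5 h is a limit, though its core differs as well. For compound 4 the expected value is 0.6 h with an estimated range from 0.25 h to 1.4 h for repeated measurements.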

Compound 4, half-life: 0.917 h
Compound 4: middle estimate off by 1.5-fold (0.18 log units), on the low side; the measured number falls inside the stated range.
By their numbers in this assay, from the lowest: compound 1; then compound 2; then compound 4. At a limit, above all of these: compound 3.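

Among the compounds shown here, this is the first single-place step: in this assay, 1-(hydroxymethyl)-1-methylethyl in place of cyclopentyl on the carbonyl carbon gives a 4.6-fold higher number from compound 2 to compound 4 (0.66 log units; beyond the scatter). With the shared core held constant, the read-out clearly responds to the group at this position. The change keeps the heavy-atom count, removes the carbon-only ring and adds 1 hydrogen-bond donor and 1 hydrogen-bond acceptor. Compound 3 remains a limit, and no step to it can be read: the limit of > 1.5 h in this assay, at which 1 of the 4 values shown sits.

Open, going by these compounds, is which part of the change carries the rise: loss of the ring, or arrival of the oxygen. Also unresolved is whether an amine or a carboxylic acid in place of the hydroxymethyl, or a longer chain ending in a hydroxyl, would move the half-life in the same direction.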